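Swapping Methyl for Iodo on an Aromatic Ring

The source may report more compounds than this note shows. Statements on the series, on what has been measured and on what is new or still open speak of the compounds shown alone.

Compound 1 `COc1cccc(-c2nn(-c3ccccc3)cc2C(Nc2nc3ccccc3s2)c2c(O)ccc3ccccc23)c1`: 24800 nM
Compound 2 `Oc1ccc2ccccc2c1C(Nc1nc2ccccc2s1)c1cn(-c2ccccc2)nc1-c1cccc(Cl)c1`: 20400 nM
Compound 3 `Cc1ccc(-c2nn(-c3ccccc3)cc2C(Nc2nc3ccccc3s2)c2c(O)ccc3ccccc23)cc1`: 57400 nM

In a functional assay on A549 cells (Homo sapiens) for antiproliferative activity, read by MTT assay, with a stated time of 48 h (a higher number here means a weaker inhibitor, a lower number a stronger inhibitor), compound 3 has the highest of the three numbers, 57400 nM, making it the weakest inhibitor so far. Compound 4 `Oc1ccc2ccccc2c1C(Nc1nc2ccccc2s1)c1cn(-c2ccccc2)nc1-c1ccc(I)cc1` carries iodo in place of methyl on an aromatic carbon, para to a large group (iodo in place of methyl on an aromatic carbon). Among the compounds with values here, no measured compound carries iodo, so the evidence is indirect. The closest comparison is the chloro-bearing compound 2, with the step of a 2.8-fold higher number from compound 2 to compound 3 (0.45 log units; beyond the scatter). The methoxy-bearing compound 1 gives a similar step, a 2.3-fold higher number from compound 1 to compound 3 (0.36 log units; beyond the scatter). A modest step to a lower number is therefore expected in this assay, a 1.8-fold lower number from compound 3 to compound 4 (0.25 log units; within the scatter). The estimate for compound 4 is 32000 nM, with an expected range of 13000 nM to 75000 nM.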

Compound 4, half-maximal inhibitory concentration: 23100 nM
Compound 4: middle estimate off by 1.4-fold (0.14 log units), on the high side, and the stated range covers the measured number.
By their numbers in this assay, from the lowest: compounds 2, 4 and 1 (each within the scatter of the next); then compound 3.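

In this assay, within the data shown here, replacing methyl with iodo at this place gives a modest change (a 2.5-fold lower number from compound 3 to compound 4 (0.40 log units; beyond the scatter)), the first step here that alters only this one group. The 4-iodophenyl group shows no clear difference from the 3-chlorophenyl group (a 1.1-fold higher number from compound 2 to compound 4 (0.05 log units; within the scatter)) or the 3-methoxyphenyl group (a 1.1-fold lower number from compound 1 to compound 4 (0.03 log units; within the scatter)), leaving compound 3 as the only one set apart. Nothing measured here accounts for the methyl-to-iodo difference. Going by these compounds, how an amine or a carboxylic acid would behave at this place remains open.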